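The source may report more compounds than this note shows. Statements on the series, on what has been measured and on what is new or still open speak of the compounds shown alone.

Measured compounds:
compound 1 `c1ccc([C@H]2CCC[C@@H](CCN3CCN(c4ccccc4)CC3)O2)cc1`, 21 nM
compound 2 `c1ccc([C@H]2CCC[C@@H](CCNCC3CCCCC3)O2)cc1`, 0.95 nM

In an assay on membranes from brain for displacement of a labelled ligand from Sigma non-opioid intracellular receptor 1 (Cavia porcellus), read by scintillation counting, with a stated time of 120 min (a lower number here means a stronger inhibitor, a higher number a weaker inhibitor), compound 1 gives 21 nM, the higher of the two numbers and therefore the weaker inhibitor of this pair. Compound 2 gives 0.95 nM in this assay, and the gap between the two lies well beyond the usual scatter. Compound 3 `c1ccc([C@@H]2CCC[C@H](CCN3CCN(c4ccccc4)CC3)O2)cc1` has not yet been measured. Its relation to compound 1 is simple: the two compounds have the same atoms and bonds and differ only in configuration as drawn: 2 of 2 stereo elements differ (all stereocentres are inverted: mirror images); a stereocentre at a saturated ring carbon is drawn R in compound 1 and S in compound 3; a stereocentre at a saturated ring carbon is drawn S in compound 1 and R in compound 3. Nothing measured here shows how mirror images of this core compare with one another, so neither the direction nor the size of the step can be read from the numbers at hand. For compound 3 the expected step from compound 1 is a 1.4-fold lower number from compound 1 to compound 3 (0.15 log units; within the scatter), a modest change carrying wide uncertainty in both directions. Compound 3 is thus expected to give about 15 nM in this assay, within a range from 3 nM to 80 nM.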

Compound 3, inhibition constant: 57 nM
Compound 3: middle estimate off by 3.8-fold (0.58 log units), on the low side; measured number inside the range.
By their numbers in this assay, from the lowest: compound 2; then compound 1; then compound 3.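

In this assay, inverting both stereocentres gives a 2.7-fold higher number from compound 1 to compound 3 (0.43 log units; beyond the scatter), so this receptor measurement does tell these two mirror images apart, although the step is modest. The step can be assigned to configuration alone because nothing else changes: the fact that compounds 1 and 3 differ only in the configuration as drawn Compound 1 therefore carries the configuration with the lower number for this side chain, a preference that the earlier pair, which differs in its side chain rather than in its configuration, could not show.

From the compounds shown here alone, it remains open whether configuration matters to the same extent with the side chain of compound 2, and what inverting only one stereocentre would do. It is also unknown whether the same preference would hold with a longer chain or with a carboxylic acid on the side chain.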